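Lengthening an Aryl Methoxy Group: Compound 3 to Compound 4

The source may hold more compounds than are shown below. What is called first, only, known or untested is meant among the compounds shown, and "the series" means these compounds.

Compound 1 `O=C(/C=C/c1ccc2c(c1)B(O)OC2)c1ccccc1` carries only hydrogen at the position in question; compound 2 `O=C(/C=C/c1ccc2c(c1)B(O)OC2)c1cccc(O)c1` bears a hydroxy there and compound 3 `COc1cccc(C(=O)/C=C/c2ccc3c(c2)B(O)OC3)c1` a methoxy. In a functional assay on SK-OV-3 cells (Homo sapiens) for cytotoxicity, read by MTT assay, with a stated time of 48 h (on this read-out higher numbers stand for weaker inhibition and lower numbers for stronger inhibition), compound 1 gives 3400 nM, compound 2 gives 3800 nM and compound 3 gives 2600 nM. The step of a 1.1-fold higher number from compound 1 to compound 2 (0.05 log units; within the scatter) and the step of a 1.3-fold lower number from compound 1 to compound 3 (0.12 log units; within the scatter) are both small, as is a 1.5-fold lower number from compound 2 to compound 3 (0.16 log units; within the scatter), so compound 3 sits together with the other two inside the usual scatter and no ranking among the three can be read from these numbers. Compound 4 `COCOc1cccc(C(=O)/C=C/c2ccc3c(c2)B(O)OC3)c1` has not yet been measured; it differs from compound 3 by methoxy in place of hydrogen on a saturated chain carbon bound to an oxygen on an aromatic ring. Within the data shown here, no measured step touches this saturated carbon, so the only guidance is that exchanging hydrogen, hydroxy and methoxy on the aromatic ring moved the number little, as in a 1.3-fold lower number from compound 1 to compound 3 (0.12 log units; within the scatter). A step of about a 1.2-fold higher number from compound 3 to compound 4 (0.06 log units; within the scatter) is therefore expected, nothing beyond the scatter. Compound 4 is estimated at 3000 nM, with a range from 1300 nM to 7000 nM.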

Compound 4, half-maximal inhibitory concentration: 11700 nM
Estimate against measurement, compound 4: 3.9-fold (0.59 log units) below; measured number above the stated range.
By their numbers in this assay, from the lowest: compounds 3, 1 and 2 (each within the scatter of the next); then compound 4.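

In this assay, among these compounds, hydrogen, hydroxy and methoxy on the aromatic ring gave numbers within the scatter of one another, but lengthening methoxy to methoxymethoxy produces the first step here that lies beyond it (a 4.5-fold higher number from compound 3 to compound 4 (0.65 log units; beyond the scatter)). The change also separates compound 4 from the other two compounds (a 3.1-fold higher number from compound 2 to compound 4 (0.49 log units; beyond the scatter); a 3.4-fold higher number from compound 1 to compound 4 (0.54 log units; beyond the scatter)), making it the weakest of the four and showing that this position does not accept every oxygen-bearing group equally. The data shown offer no measurement that explains this loss.

As far as these compounds go, whether the weaker result goes with the longer chain itself or with its added oxygen stays open, and an ethoxy or propoxy group could help separate the two. From the compounds shown here alone, how an amine or a carboxylic acid at this position would behave also remains unknown.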